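The compounds below may be only part of what the source reports. "The series", "measured", "known", "first", "only" and "open" are said of these compounds alone.

Compound 3 `CC(C)(C)CNCCS(=O)(=O)NC(=O)c1ccc(Nc2nc(NC3(c4ccc(Cl)cc4)CC3)nc(OCC(F)(F)F)n2)cc1` gives the highest number of the three in a physicochemical assay for permeability, using PAMPA, at pH 7.4 (on this read-out lower numbers stand for lower permeability and higher numbers for higher permeability), at 651 nm/s; compound 1 `O=C(NS(=O)(=O)c1ccc(F)cc1)c1ccc(Nc2nc(NC3(c4ccc(Cl)cc4)CC3)nc(OCC(F)(F)F)n2)cc1` gives 193 nm/s and compound 2 `CC(C)C(=O)NCCS(=O)(=O)NC(=O)c1ccc(Nc2nc(NC3(c4ccc(Cl)cc4)CC3)nc(OCC(F)(F)F)n2)cc1` gives 13 nm/s. Compound 4 `O=C(NS(=O)(=O)CCNCc1ccccc1)c1ccc(Nc2nc(NC3(c4ccc(Cl)cc4)CC3)nc(OCC(F)(F)F)n2)cc1` has not been measured; it differs from compound 3 by phenyl in place of tert-butyl on a saturated chain carbon bound to an amine nitrogen. For the measured compounds named here, no measured step alters that group alone. Going by the values given here, the steps that bear on it are a 50-fold higher number from compound 2 to compound 3 (1.70 log units; beyond the scatter) and a 3.4-fold higher number from compound 1 to compound 3 (0.53 log units; beyond the scatter); both change what sits on the sulfonyl sulfur or the amine nitrogen, and the amine of compound 3 is retained in compound 4. A step in this assay no larger than a modest one, downward if anything, is therefore expected, a 1.4-fold lower number from compound 3 to compound 4 (0.16 log units; within the scatter). For compound 4 the estimate is 450 nm/s, with a range from 200 nm/s to 1000 nm/s.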

Compound 4, apparent permeability: 49 nm/s
Compound 4: middle estimate off by 9.2-fold (0.96 log units), on the high side; the whole stated range lies above it.
By their numbers in this assay, from the lowest: compound 2; then compound 4; then compound 1; then compound 3.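

In this assay, keeping the amine does not keep the high number: benzyl in place of neopentyl on that nitrogen gives a large fall (a 13-fold lower number from compound 3 to compound 4 (1.12 log units; beyond the scatter)). The comparison with the 4-fluorophenyl compound also reverses, since 2-(benzylamino)ethyl on the sulfonyl sulfur lowers the number (a 3.9-fold lower number from compound 1 to compound 4 (0.60 log units; beyond the scatter)), although benzyl still beats isopropylcarbonyl on the amine nitrogen (a 3.8-fold higher number from compound 2 to compound 4 (0.58 log units; beyond the scatter)). Nothing available accounts for the gap between neopentyl and benzyl. On these data alone, whether cyclohexylmethyl on the amine nitrogen would read nearer compound 3 or compound 4 stays open, which leaves saturated ring and aromatic ring unseparated at this place.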